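A few compounds are considered here, and "the series" means these few. Any claim that something is new, unique, unknown or untested is made for them only; others in the source may bear on it.

Three compounds of the series have numbers in an ADME assay on HEL cells (Homo sapiens) for cytotoxicity, with a stated time of 3 days; on this read-out lower numbers stand for higher toxicity in this test and higher numbers for lower toxicity in this test. Compound 1 `C=Cc1ccc(-c2cc(C)c3ncc(CSCCc4ccccc4)n3c2)cc1` gives 14 ug/mL and compound 2 `Cc1cc(C#N)cn2c(CSCCc3ccccc3)cnc12` gives 14 ug/mL; the step of no change at the digits printed from compound 1 to compound 2 (within the scatter) sits on the same aromatic carbon that is varied below. Compound 3 `Cc1cc(-c2ccoc2)c2ncc(CSCCc3ccccc3)n2c1` gives 64 ug/mL, the highest of the three numbers, with a gap beyond the scatter to both compound 1 and compound 2. Compound 4 `Cc1cc(Sc2ccc(O)cc2)c2ncc(CSCCc3ccccc3)n2c1` is not yet measured. The change is (4-hydroxyphenyl)sulfanyl in place of furan-3-yl on an aromatic carbon. Among the measured compounds shown here, only the step from compound 1 to compound 2 bears on it, and that step showed no change, whereas the numbers of compound 1 and compound 3 show that a group at this carbon can move the value beyond the scatter. A modest downward step, a 2.0-fold lower number from compound 3 to compound 4 (0.30 log units; within the scatter), is therefore expected. Compound 4 is estimated at 32 ug/mL, between 10 ug/mL and 90 ug/mL.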

Compound 4, half-maximal cytotoxic concentration: 79 ug/mL
Beside the measured number, compound 4's estimate is 2.5-fold (0.39 log units) below it, within the range that was stated.
By their numbers in this assay, from the lowest: compounds 1 and 2 (each within the scatter of the next); then compounds 3 and 4 (each within the scatter of the next).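

In this assay, (4-hydroxyphenyl)sulfanyl in place of furan-3-yl on this aromatic carbon gives a 1.2-fold higher number from compound 3 to compound 4 (0.09 log units; within the scatter) and so leaves the read-out within the scatter. At this carbon, a larger group with a sulfur atom, a six-membered aromatic ring and a hydrogen-bond donor reads the same as the five-membered ring it replaces. No supporting data bear on why the read-out holds here. Open, going by these compounds, is whether an amine or a carboxylic acid on this carbon would hold the value as well. Also open, on these data alone, is how the hydroxy group and the sulfur each contribute on their own.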